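Shortening the Bromoalkyl Chain on the Shared Core

A few compounds are considered here, and "the series" means these few. Any claim that something is new, unique, unknown or untested is made for them only; others in the source may bear on it.

Compound 2 `COc1ccc(-c2coc3cc(OCCCCCBr)ccc3c2=O)cc1` gives 44800 nM in a functional assay on PC-3 cells (Homo sapiens) for inhibition, read by MTT assay, with a stated time of 48 h (a higher number here means a weaker inhibitor, a lower number a stronger inhibitor), the higher of the two numbers shown, though only within the scatter of compound 1. Compound 1 `COc1ccc(-c2coc3cc(OCCCSC(=S)N4CCOCC4)ccc3c2=O)cc1` gives 27400 nM in this assay. Within the data shown here, the single measured step, a 1.6-fold higher number from compound 1 to compound 2 (0.21 log units; within the scatter), replaced the group at the chain end and stayed within the scatter. Compound 3 `COc1ccc(-c2coc3cc(OCCCCBr)ccc3c2=O)cc1` differs from compound 2 by bromo in place of bromomethyl on a saturated chain carbon, four bonds along the chain from an oxygen on an aromatic ring. Among the measured compounds shown here, no measured step shortens the chain, so there is no direct guide. For compound 3 the expected step is a 1.0-fold higher number from compound 2 to compound 3 (0.00 log units; within the scatter), nothing beyond the scatter. Compound 3 is therefore estimated at 45000 nM, with a range from 20000 nM to 100000 nM.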

Compound 3, half-maximal inhibitory concentration: 55600 nM
Estimate against measurement, compound 3: 1.2-fold (0.09 log units) below, within the range that was stated.
By their numbers in this assay, from the lowest: compounds 1, 2 and 3 (each within the scatter of the next, the first and the last beyond it).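

Taking one carbon out of the bromoalkyl chain, bromo in place of bromomethyl, gives a 1.2-fold higher number from compound 2 to compound 3 (0.09 log units; within the scatter) in this assay and so produces no clear response at this position. Among these compounds, the larger replacement of the whole chain-end group gives a 2.0-fold higher number from compound 1 to compound 3 (0.31 log units; beyond the scatter) and is the first step here to pass the scatter, though only modestly. Nothing available explains either step.

From the compounds shown here alone, whether an amine or a carboxylic acid at the chain end would shift the number further remains open. So does the effect of a longer chain on the shared core.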